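Isobutyl addition on the nitro analogue: expected shift

The source may hold more compounds than are shown below. What is called first, only, known or untested is meant among the compounds shown, and "the series" means these compounds.

Measured in a functional assay, read by spectrophotometry, with a stated time of 20 min; on this read-out lower numbers stand for stronger inhibition and higher numbers for weaker inhibition:
compound 1 `CC(=O)c1ccc(NC(=O)CN(C(=O)c2ccccc2)S(=O)(=O)c2ccc(C)cc2)cc1` gives 102000000 nM
compound 2 `CC(=O)c1ccc(NC(=O)C(CC(C)C)N(C(=O)c2ccccc2)S(=O)(=O)c2ccc(C)cc2)cc1` gives 11000000 nM
compound 3 `CC(=O)c1ccc(NC(=O)CN(C(=O)c2ccccc2)S(=O)(=O)c2ccc([N+](=O)[O-])cc2)cc1` gives 58000000 nM

Compound 3 holds the second highest of the three numbers in this assay. Its nearest neighbour is compound 1, at a 1.8-fold lower number from compound 1 to compound 3 (0.25 log units; within the scatter), a step that stays within the scatter, so the two cannot be told apart. Compound 2 stands furthest from it, and that gap lies beyond the scatter.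

Compound 4 `CC(=O)c1ccc(NC(=O)C(CC(C)C)N(C(=O)c2ccccc2)S(=O)(=O)c2ccc([N+](=O)[O-])cc2)cc1` is reached from compound 3 by a single change: isobutyl in place of hydrogen on a saturated chain carbon bound to an amide-type nitrogen and a carbonyl carbon. For the measured compounds named here, the one measured step that bears on this change is the same substitution made on the methyl-bearing core, a 9.3-fold lower number from compound 1 to compound 2 (0.97 log units; beyond the scatter), a modest move that nonetheless exceeds the scatter. Nothing measured shows the nitro and isobutyl changes together, so the expectation rests on carrying the step from compound 1 to compound 2 over unchanged.

On that basis compound 4 is expected to give a lower number in this assay than compound 3, with the expected step being a 9.4-fold lower number from compound 3 to compound 4 (0.97 log units; beyond the scatter). The estimate for compound 4 is 6200000 nM, with a likely range from 2000000 nM to 20000000 nM.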

Compound 4, half-maximal inhibitory concentration: 8400000 nM
The estimate for compound 4 lay 1.4-fold (0.13 log units) below the measured number; measured number inside the range.
By their numbers in this assay, from the lowest: compounds 4 and 2 (each within the scatter of the next); then compounds 3 and 1 (each within the scatter of the next).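

In this assay, isobutyl in place of hydrogen on a saturated chain carbon bound to an amide-type nitrogen and a carbonyl carbon now holds on a second core, with a 6.9-fold lower number from compound 3 to compound 4 (0.84 log units; beyond the scatter), so the gain at this position no longer rests on a single pair, and the two steps agree: the same change on two cores in this assay, a 9.3-fold lower number (0.97 log units; beyond the scatter) from compound 1 to compound 2 and a 6.9-fold lower number (0.84 log units; beyond the scatter) from compound 3 to compound 4, 1.3-fold (0.13 log units) apart, within the scatter of two such steps. The aromatic change also stays within the scatter once isobutyl is present, with nitro in place of methyl giving a 1.3-fold lower number from compound 2 to compound 4 (0.12 log units; within the scatter), and it reads the same on both cores: the same change on two cores in this assay, a 1.8-fold lower number (0.25 log units; within the scatter) from compound 1 to compound 3 and a 1.3-fold lower number (0.12 log units; within the scatter) from compound 2 to compound 4, 1.3-fold (0.13 log units) apart, within the scatter of two such steps. Across these four compounds the two changes behave as independent of each other, the isobutyl step lying beyond the scatter on both cores and the nitro step within it on both.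

Still open, on these data alone, is whether the gain is particular to isobutyl, since a longer chain, a benzyl group or a carboxylic acid on the same carbon would show how far it extends. On the aromatic carbon only methyl and nitro are compared, so an amine or a chlorine there could yet give a step beyond the scatter.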